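The compounds below may be only part of what the source reports. "The series", "measured", "known", "first", "only" and "open" are said of these compounds alone.

Three compounds of one series have numbers in a functional assay on CHO cells for antagonist activity at prostaglandin E2 receptor EP3 subtype (Homo sapiens), read by FLIPR, with a stated time of 1 h; on this read-out higher numbers stand for weaker inhibition and lower numbers for stronger inhibition. Compound 1 `O=C1NC(=O)C(c2ccc(-c3ccc4ccccc4c3)[nH]c2=O)(C2CC2)O1` gives 50.1 nM. Compound 2 `CC(C)C1(c2c[nH]c(-c3ccc4ccccc4c3)cc2=O)OC(=O)NC1=O` gives 794 nM. Compound 3 `CC(C)C1(c2cc(Br)c(-c3ccc4ccccc4c3)[nH]c2=O)OC(=O)NC1=O` gives 39.8 nM; compound 1 sits within the scatter of compound 3, whereas compound 2 lies well beyond it. Compounds 2 and 3 differ in more than one place, so no single-change step can be read from that pair. The next compound, compound 4 `CC(C)C1(c2cc(C(F)(F)F)c(-c3ccc4ccccc4c3)[nH]c2=O)OC(=O)NC1=O`, carries trifluoromethyl in place of bromo on an aromatic carbon. For the measured compounds named here, no step between measured compounds bears on this exchange, so the expectation rests on compound 3 alone. In this assay compound 4 is expected near 40 nM, with a range of 15 nM to 120 nM. The step of a 1.0-fold higher number from compound 3 to compound 4 (0.00 log units; within the scatter) this implies is expected to stay within the scatter, with no direction beyond it.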

Compound 4, inhibition constant: 631 nM
Beside the measured number, compound 4's estimate is 16-fold (1.20 log units) below it; measured number above the stated range.
By their numbers in this assay, from the lowest: compounds 3 and 1 (each within the scatter of the next); then compounds 4 and 2 (each within the scatter of the next).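

In this assay, for the compounds shown here, the exchange gives a 16-fold higher number from compound 3 to compound 4 (1.20 log units; beyond the scatter) and is the first single-change step. It shows that this position, two atoms from the ring nitrogen, does not treat bromo and trifluoromethyl as interchangeable, and that a single substituent exchange here can move the number well beyond the scatter. Nothing at hand accounts for this difference between the two groups.

From the compounds shown here alone, how chloro, methyl, nitrile or an amine would read at this position remains open. Also open, going by these compounds, is whether the same exchange gives a step of similar size on another core.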